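Adding a Methoxy Group to a Branched Ester Chain

A few compounds are considered here, and "the series" means these few. Any claim that something is new, unique, unknown or untested is made for them only; others in the source may bear on it.

Compound 1 `CCCOC(=O)/C=C(C)/C=C/CC(C)CCCC(C)C` and compound 2 `CCCOC(=O)/C=C(C)/C=C/CC(C)CCCC(C)(C)OC` share one core and differ in one place: methoxy in place of hydrogen on a saturated chain carbon bound to three saturated chain carbons. In a physicochemical assay for lipophilicity (a lower number here means a more polar compound, a higher number a more lipophilic compound), compound 1 gives 7.28, while compound 2 gives 6.08, so that this change made a number 1.20 log units lower from compound 1 to compound 2 (beyond the scatter).

Compound 3 `CCOC(=O)/C=C(C)/C=C/CC(C)CCC(OC)C(C)C` has a different core; how its core differs from that of compound 1 is not broken down here. In this assay compound 3 gives 5.54.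

Compound 4 `CCOC(=O)/C=C(C)/C=C/CC(C)CCC(OC)C(C)(C)OC` is not yet measured. It differs from compound 3 by the same change as before: methoxy in place of hydrogen on a saturated chain carbon bound to three saturated chain carbons, at a place described in the same words.

Because the earlier change gave a number 1.20 log units lower from compound 1 to compound 2 (beyond the scatter), a step of similar size is expected here, a number 1.14 log units lower from compound 3 to compound 4 (beyond the scatter). Compound 4 is therefore estimated at 4.4, between 3.9 and 4.9.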

Compound 4, partition coefficient: 4.34
For compound 4 the middle estimate is 0.06 log units above the measured one; low and high end bracket the measured number.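

In this assay the methoxy change gave a number 1.20 log units lower from compound 3 to compound 4 (beyond the scatter), matching a number 1.20 log units lower from compound 1 to compound 2 (beyond the scatter), so the step carried over at the same size from the core of compound 1 to the core of compound 3. Among the compounds shown here, that is only one pair on each of two cores, so it does not show that the step will hold on any other core. Nothing available here explains why the two steps match.

The compounds shown leave open whether an ethoxy group or an amine in place of the same hydrogen would give a step of similar size. They also leave open whether the methoxy step would hold on a core with a longer chain.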